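Ester-side variation on the shared core: toward compound 4

The compounds below may be only part of what the source reports. "The series", "measured", "known", "first", "only" and "open" are said of these compounds alone.

Among the measured compounds shown here, compound 3 `O=C(OC1(C(=O)Nc2ccc([N+](=O)[O-])cc2)CCCCC1)c1ccccc1` gives 903 nM in a functional assay on MCF7 cells (Homo sapiens) for inhibition, read by MTT assay, with a stated time of 72 h (on this read-out higher numbers stand for weaker inhibition and lower numbers for stronger inhibition), and stands at the highest of the three numbers so far. Compound 2 `O=C(OC1(C(=O)Nc2ccc([N+](=O)[O-])cc2)CCCCC1)c1ccccc1I` gives 619 nM; the step of a 1.5-fold higher number from compound 2 to compound 3 (0.16 log units; within the scatter) lies within the scatter. Compound 1 `O=C(OC1(C(=O)Nc2ccc([N+](=O)[O-])cc2)CCCCC1)c1ccc(Cl)cc1` gives 15 nM, and the step of a 60-fold higher number from compound 1 to compound 3 (1.78 log units; beyond the scatter) is large, as is a 41-fold higher number from compound 1 to compound 2 (1.62 log units; beyond the scatter). Compound 4 `O=C(OC1(C(=O)Nc2ccc([N+](=O)[O-])cc2)CCCCC1)C(O)c1ccccc1` differs from compound 3 by hydroxy(phenyl)methyl in place of phenyl on a carbonyl carbon. For the measured compounds named here, none of the measured steps touches this position; each of them exchanges a chloro or iodo on the phenyl, so none bears directly on the change. Going by the values given here, with no step to lean on, the expected step of a 1.0-fold lower number from compound 3 to compound 4 (0.00 log units; within the scatter) is none beyond the scatter. Compound 4 is estimated at 900 nM, with a range from 250 nM to 3500 nM.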

Compound 4, half-maximal inhibitory concentration: 5.01 nM
Compound 4: middle estimate off by 180-fold (2.25 log units), on the high side, outside the stated range (below it).
By their numbers in this assay, from the lowest: compound 4; then compound 1; then compounds 2 and 3 (each within the scatter of the next).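

In this assay, change at the carbonyl carbon itself moves the number far more than the halogen exchanges on the phenyl suggested: hydroxy(phenyl)methyl in place of phenyl gives a 180-fold lower number from compound 3 to compound 4 (2.26 log units; beyond the scatter), and in place of 2-iodophenyl gives a 120-fold lower number from compound 2 to compound 4 (2.09 log units; beyond the scatter). Against 4-chlorophenyl the step is smaller, a 3.0-fold lower number from compound 1 to compound 4 (0.48 log units; beyond the scatter), so a low number here does not depend on a chloro on the ring. Nothing at hand explains these steps.

Open, going by these compounds, is whether the hydroxy or the added carbon carries the step, and how an amine or a methoxy on that carbon would read. Also open, on these data alone, is whether a chloro on the phenyl of hydroxy(phenyl)methyl would add to the step.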